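Aryl versus acrylamide at the benzyl terminus

This account rests on a few compounds, and the source may have more. Where it says the series, first, only, none or still open, it means among the compounds named here.

Compound 1 `COC(=O)/C=C/c1cccc(N(Cc2ccc(-c3ccc(OC)cc3)cc2)C(=O)C2CCCCC2)c1` sets the reference in an assay on isolated protein with Bile acid receptor (Homo sapiens) as the target (on this read-out lower numbers stand for an effect already at smaller amounts and higher numbers for an effect only at larger amounts of compound), where compound 1 gives 89 nM. Compound 2 `COC(=O)/C=C/c1cccc(N(Cc2ccc(/C=C/C(=O)NC(C)(C)C)cc2)C(=O)C2CCCCC2)c1` keeps the shared core. In this assay compound 2 reaches only the limit of the assay, > 1000 nM, not a number. For the measured compounds named here, the single measured step is an at least 11-fold higher number from compound 1 to compound 2 (1.05 log units; beyond the scatter), read against (the limit of > 1000 nM in this assay, at which 1 of the 2 values shown sits), so compound 2 stands at the weak end of the two values shown. Compound 3 `COC(=O)/C=C/c1cccc(N(Cc2ccc(-c3ccc(OC(F)(F)F)cc3)cc2)C(=O)C2CCCCC2)c1` is not yet measured in this assay. Its difference from compound 2 is computed as follows. 4-(trifluoromethoxy)phenyl in place of 2-((tert-butyl)carbamoyl)ethenyl on an aromatic carbon The change brings back a phenyl group, as in compound 1 with its 4-methoxyphenyl, so a step back toward the number of compound 1 is expected, namely an at least 11-fold lower number from compound 2 to compound 3 (1.04 log units; beyond the scatter). Compound 3 is therefore estimated at 90 nM, with a range from 30 nM to 300 nM.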

Compound 3, half-maximal effective concentration: 264 nM
Compound 3: the middle estimate sits 2.9-fold (0.47 log units) below what was measured; the measured number falls inside the stated range.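

Compound 2 stands at a limit of the assay, not at a number: the limit of > 1000 nM in this assay, at which 1 of the 3 values shown sits.
Measured against that limit, 4-(trifluoromethoxy)phenyl at this aromatic carbon gives an at least 3.7-fold lower number from compound 2 to compound 3 (0.57 log units; beyond the scatter), so both compounds with an aryl group here, compound 1 and compound 3, read lower than the acrylamide compound 2. The group on the aryl oxygen also moves the number, as trifluoromethyl in place of methyl gives a 3.0-fold higher number from compound 1 to compound 3 (0.47 log units; beyond the scatter).

An unsubstituted phenyl, or a phenyl bearing an amine or a carboxylic acid, would help separate the contribution of the ring from that of its oxygen substituent. As far as these compounds go, it also remains open whether the weak reading of compound 2 follows from the tert-butyl amide or from the ethenyl link, which a simple ethyl ester on the same ethenyl chain would help to separate.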